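From methyl to cyclopropyl on a shared core

The source may report more compounds than this note shows. Statements on the series, on what has been measured and on what is new or still open speak of the compounds shown alone.

Measured in an ADME assay on LLC-PK1 cells (Sus scrofa) for permeability, read by LC-MS, with a stated time of 2 h, tested at 5 uM; a lower number here means that the compound crosses the layer more slowly, a higher number that the compound crosses the layer faster
- Compound 1 `Cc1cc2c(cn1)Oc1ccc(NC(=O)c3ccc(Cl)cn3)cc1[C@@]21COC(N)=N1` gives 40 nm/s
- Compound 2 `NC1=N[C@@]2(CO1)c1cc(-c3cncc(C#CCO)c3)ccc1Oc1cnc(C3=CCOCC3)cc12` gives 15 nm/s

Of the two, compound 1 stands higher with 40 nm/s against compound 2 with 15 nm/s and the gap lies beyond the scatter. Compound 3 `NC1=N[C@@]2(CO1)c1cc(NC(=O)c3ccc(Cl)cn3)ccc1Oc1cnc(C3CC3)cc12` differs from compound 1 in one place, with cyclopropyl in place of methyl on an aromatic carbon and the rest of the core unchanged. Going by the values given here, no pair of measured compounds differs in one place only, so the data hold no direct guide to this change. In this assay no step beyond the scatter is expected. The estimated change is slight and upward (a 1.1-fold higher number from compound 1 to compound 3 (0.05 log units; within the scatter)) and stays within the scatter. Compound 3 is expected near 45 nm/s with a range of 18 nm/s to 100 nm/s on this estimate.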

Compound 3, apparent permeability: 29 nm/s
The estimate for compound 3 lay 1.6-fold (0.19 log units) above the measured number; the range from low to high includes it.
By their numbers in this assay, from the lowest: compounds 2, 3 and 1 (each within the scatter of the next, the first and the last beyond it).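

With compound 3, the shared core gains its first one-place comparison in this assay, and the step is a 1.4-fold lower number from compound 1 to compound 3 (0.14 log units; within the scatter). On an aromatic carbon next to the ring nitrogen, exchanging methyl, a single carbon, for cyclopropyl, three carbons in a three-membered ring, therefore produces no step beyond the scatter in this read-out, although the group is larger and adds a ring. No measurement available here bears on the reason for this result.

The compounds shown leave open whether a group of another kind at this position, such as an amine, a methoxy group or a longer alkyl chain, would move the number beyond the scatter. They also leave open whether the exchange of methyl for cyclopropyl would give a similar step with a different amide portion on the core.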